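Bromo for tert-Butyl on Two Related Cores

The source may report more compounds than this note shows. Statements on the series, on what has been measured and on what is new or still open speak of the compounds shown alone.

Measured so far:
Compound 1, `COc1ccc(/C=C2/CN(C)/C(=N/c3ccc(C(C)(C)C)cc3)S2)cc1`, gives 25900 nM.
Compound 2, `COc1ccc(/C=C2/CN(C)/C(=N/c3ccc(Br)cc3)S2)cc1`, gives 8900 nM.
Compound 3, `COc1ccc(/C=C2\S/C(=N\c3ccc(C(C)(C)C)cc3)N(C)C2=O)cc1`, gives only a limit of the assay, > 100000 nM.

All three values come from a functional assay on HCT-116 cells (Homo sapiens) for antiproliferative activity, read by MTT assay, with a stated time of 72 h; on this read-out higher numbers stand for weaker inhibition and lower numbers for stronger inhibition. Compound 1 and compound 2 share one core and differ in a single place: bromo in place of tert-butyl on an aromatic carbon. That change made the step of a 2.9-fold lower number from compound 1 to compound 2 (0.46 log units; beyond the scatter), so here the bromo compound gave the stronger inhibition.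

Compound 3 is built on a second core, and the difference between the two cores is not broken down here. Compound 3 does not yield a number at all; it sits at the limit of > 100000 nM in this assay, at which 1 of the 3 values shown sits. Compound 4, `COc1ccc(/C=C2\S/C(=N\c3ccc(Br)cc3)N(C)C2=O)cc1`, has not yet been measured. It relates to compound 3 exactly as compound 2 relates to compound 1: bromo in place of tert-butyl on an aromatic carbon. The place of the change reads the same in both pairs, so this is the same change on a different core.

Because compound 3 gives only > 100000 nM, the size of the step to compound 4 cannot be read from a measured number. If the change acts as it did in a 2.9-fold lower number from compound 1 to compound 2 (0.46 log units; beyond the scatter), compound 4 is expected to land somewhat better than the limit, and the estimated step is an at least 1.6-fold lower number from compound 3 to compound 4 (0.22 log units; that floor lies within the scatter). Compound 4 is therefore estimated at 60000 nM, with the plausible span 20000 nM to 150000 nM, and a real chance that it, too, returns only a limit.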

Compound 4, half-maximal inhibitory concentration: 17000 nM
Estimate against measurement, compound 4: 3.5-fold (0.55 log units) above; measured number below the stated range.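

Across both pairs in this assay, bromo in place of tert-butyl on an aromatic carbon gave the lower number: the step is a 2.9-fold lower number from compound 1 to compound 2 (0.46 log units; beyond the scatter) on one core and an at least 5.8-fold lower number from compound 3 to compound 4 (0.76 log units; beyond the scatter) on the other, so the direction of the change carried over in these two pairs. Compound 3 gives > 100000 nM as a limit of the assay and not a number, and this leaves the true size of its step unknown: the limit of > 100000 nM in this assay, at which 1 of the 4 values shown sits. Whether the change is worth more on one core than on the other is therefore not shown, and two pairs make no rule for further cores: the same change on two cores in this assay, a 2.9-fold lower number (0.46 log units; beyond the scatter) from compound 1 to compound 2 and an at least 5.8-fold lower number (0.76 log units; beyond the scatter) from compound 3 to compound 4; the limit leaves it open whether they differ.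

The compounds shown carry only tert-butyl and bromo at this place on the aromatic ring, which leaves open how chloro, fluoro, a methoxy group or an amine would fare there on either core. They also leave open how the two cores would respond if the methoxy group found elsewhere in these compounds gave way to a hydroxyl group or a carboxylic acid.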